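The compounds below may be only part of what the source reports. "The series", "measured", "known", "first", "only" and "open" are said of these compounds alone.

Among the measured compounds shown here, compound 3 `CC(C)=CCC/C(C)=C/CCC1=C[C@H](c2ccc(C(C)(C)C)cc2)OC1=O` gives 5820 nM in an assay on microsomes from liver for inhibition of 3-hydroxy-3-methylglutaryl-coenzyme A reductase (Sus scrofa), read by colorimetric assay (a higher number here means a weaker inhibitor, a lower number a stronger inhibitor), the lowest of the three numbers measured so far. In this assay compound 1 `CC(C)=CCC/C(C)=C/CCC1=C[C@H](c2ccccc2)OC1=O` gives 16500 nM, and compound 2 `CC(C)=CCC/C(C)=C/CCC1=C[C@H](c2ccc(C)cc2)OC1=O` gives 18100 nM. Compound 4 `CC(C)=CCC/C(C)=C/CCC1=C[C@H](c2ccc(C(C)C)cc2)OC1=O` differs from compound 3 by hydrogen in place of methyl on a saturated chain carbon bound to an aromatic carbon and two saturated chain carbons. For the measured compounds named here, two measured steps bear on this change: a 2.8-fold lower number from compound 1 to compound 3 (0.45 log units; beyond the scatter), and a 3.1-fold lower number from compound 2 to compound 3 (0.49 log units; beyond the scatter), while a 1.1-fold higher number from compound 1 to compound 2 (0.04 log units; within the scatter). Since isopropyl lies between methyl and tert-butyl in the count of carbons, part of the drop seen with tert-butyl is expected to be given back, so a modest rise in the number is expected, smaller than either of those steps. The expected step is a 1.5-fold higher number from compound 3 to compound 4 (0.19 log units; within the scatter). Compound 4 is therefore estimated at 9000 nM, with a range from 5000 nM to 17000 nM.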

Compound 4, half-maximal inhibitory concentration: 112000 nM
Beside the measured number, compound 4's estimate is 12-fold (1.09 log units) below it; measured number above the stated range.
By their numbers in this assay, from the lowest: compound 3; then compounds 1 and 2 (each within the scatter of the next); then compound 4.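

In this assay, among the compounds shown here, the change from tert-butyl to isopropyl gives a 19-fold higher number from compound 3 to compound 4 (1.28 log units; beyond the scatter) and shows that one methyl on this saturated chain carbon can matter far more than the earlier steps suggested. Isopropyl also falls behind the smaller groups, with a 6.2-fold higher number from compound 2 to compound 4 (0.79 log units; beyond the scatter) and a 6.8-fold higher number from compound 1 to compound 4 (0.83 log units; beyond the scatter) in this assay so the numbers do not follow the count of carbons, and compound 4 is the clear exception and the weakest of the set. Nothing available explains this result. As far as these compounds go, whether the loss is particular to isopropyl remains open. An ethyl group or a cyclopropyl ring in the same place could show how narrow this requirement is.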